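Swapping the halogenated ring for a methylphenyl ring

The source may hold more compounds than are shown below. What is called first, only, known or untested is meant among the compounds shown, and "the series" means these compounds.

Measured compounds:
compound 1 `COc1ccc(CN(C(=O)Nc2ccc(F)c(Cl)c2)n2cnnc2)cc1OC`, 20700 nM
compound 2 `N#Cc1ccc(CN(C(=O)Nc2cc(C(F)(F)F)cc(C(F)(F)F)c2)n2cnnc2)cc1`, 4510 nM

Among the measured compounds shown here, in a functional assay on B16-F10 cells (Mus musculus) for cytotoxicity, read by MTT assay, with a stated time of 48 h (a lower number here means a stronger inhibitor, a higher number a weaker inhibitor), compound 1 gives 20700 nM, the higher of the two numbers known so far. Compound 2, which differs from it in several places at once, gives 4510 nM, a gap beyond the usual scatter. Compound 3 `COc1ccc(CN(C(=O)Nc2ccc(C)cc2)n2cnnc2)cc1OC` is the unmeasured partner of compound 1. The change is 4-methylphenyl in place of 3-chloro-4-fluorophenyl on an amide-type nitrogen. Two halogens leave the ring and a single methyl enters. With no directly comparable step known, the size of the change cannot be read from other pairs. The expectation for the step from compound 1 to compound 3 in this assay is a 1.2-fold higher number from compound 1 to compound 3 (0.08 log units; within the scatter), within the scatter and with no firm direction. Compound 3 is therefore estimated at 25000 nM, with a range from 8000 nM to 80000 nM.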

Compound 3, half-maximal inhibitory concentration: 29900 nM
Compound 3: middle estimate off by 1.2-fold (0.08 log units), on the low side; the measured number falls inside the stated range.
By their numbers in this assay, from the lowest: compound 2; then compounds 1 and 3 (each within the scatter of the next).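

In this assay, among the compounds shown here, the swap of 3-chloro-4-fluorophenyl for 4-methylphenyl on the amide-type nitrogen reads as a 1.4-fold higher number from compound 1 to compound 3 (0.16 log units; within the scatter) and is the first single-place comparison in this set. On this pair, then, two halogens on the ring and a single methyl cannot be told apart in this cell test, since the two numbers lie within normal repeat variation. No accompanying measurement bears on this result, so it offers no explanation for it.

As far as these compounds go, whether a ring carrying an amine or a carboxylic acid at this place would shift the number beyond that variation remains open. Compound 2 also differs from compound 1 in several places at once, so the separate contributions of its trifluoromethyl and nitrile groups cannot be read from these compounds.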